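This account rests on a few compounds, and the source may have more. Where it says the series, first, only, none or still open, it means among the compounds named here.

Measured compounds:
Compound 1, `C=CCNc1nnc(SCC(=O)N(Cc2cccc([N+](=O)[O-])c2)c2ccc(F)cc2)s1`, an assay on isolated protein for inhibition of Amine oxidase [flavin-containing] A (Homo sapiens), read by fluorescence and Amplex Red, with a stated time of 30 min, tested at 0.1 uM; on this read-out higher numbers stand for a stronger effect at the one concentration tested and lower numbers for a weaker effect: 43.2%
Compound 2, `COCCNc1nnc(SCC(=O)N(Cc2cccc([N+](=O)[O-])c2)c2ccc(F)cc2)s1`, this assay: 61.1%

Compound 1 stands lowest of the two numbers measured; its nearest neighbour is compound 2, reached by the step of a number 17.9 percentage points higher from compound 1 to compound 2 (beyond the scatter). Among the measured compounds shown here, that step alters the group on a saturated chain carbon bound to a nitrogen on an aromatic ring, and it is the only measured step available for comparison.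

Compound 3, `CCNc1nnc(SCC(=O)N(Cc2cccc([N+](=O)[O-])c2)c2ccc(F)cc2)s1`, differs from compound 1 at the same place: methyl in place of vinyl on a saturated chain carbon bound to a nitrogen on an aromatic ring. The step from compound 1 to compound 2 bears on it, since both steps remove the vinyl from that chain carbon, but what enters differs: there a methoxymethyl, here a methyl. The measured step was modest and beyond the scatter, so a change of that kind in the same direction is plausible, though with a smaller incoming group a smaller step, or none beyond the scatter, cannot be ruled out.

Compound 3 is therefore expected to give about 48% in this assay, within a range of 30% to 66%. The expected step from compound 1 is a number 4.8 percentage points higher from compound 1 to compound 3 (within the scatter).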

Compound 3, a percentage reported as inhibition, at one concentration (the size of the read-out at that concentration, not a potency): 42.1%
Estimate against measurement, compound 3: 5.9 percentage points above, within the range that was stated.
By their numbers in this assay, from the lowest: compounds 3 and 1 (each within the scatter of the next); then compound 2.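

In this assay, the exchange of vinyl for methyl on a saturated chain carbon bound to a nitrogen on an aromatic ring reads as a number 1.1 percentage points lower from compound 1 to compound 3 (within the scatter), so the read-out does not separate allylamino from ethylamino, even though the double bond outside aromatic rings and one carbon leave with the vinyl. The methoxy group now has a direct comparison: hydrogen in place of methoxy on a saturated chain carbon, two bonds along the chain from a nitrogen on an aromatic ring, gives a number 19 percentage points lower from compound 2 to compound 3 (beyond the scatter), and among these three only compound 2 stands apart from the other two by steps beyond the scatter. No available evidence bears on the reason for this result.

As far as these compounds go, it remains open whether this step depends on the oxygen of the methoxy or on the length of the chain, a question that a propyl or butyl group at this place would address. From the compounds shown here alone, how a hydroxy group or an amine at the end of the chain would read also remains open.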